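A few compounds are considered here, and "the series" means these few. Any claim that something is new, unique, unknown or untested is made for them only; others in the source may bear on it.

In a functional assay on MOLT-4 cells (Homo sapiens) for inhibition, read by MTT assay, with a stated time of 72 h (on this read-out higher numbers stand for weaker inhibition and lower numbers for stronger inhibition), compound 1 (`COc1cc(NC(C)CCCNC(=O)Nc2ccc(Br)cc2)c2ncccc2c1`) gives 25000 nM as its value. In the same read-out compound 2 (`COc1cc(NC(C)CCCNC(=O)Nc2cccc(O)c2)c2ncccc2c1`) gives 24000 nM as its value. Within the data shown here, compound 2 therefore stands level with compound 1, the only other measured compound, and neither can be ranked above the other. Among the measured compounds shown here, the single measured step, a 1.0-fold lower number from compound 1 to compound 2 (0.02 log units; within the scatter), exchanges 4-bromophenyl for 3-hydroxyphenyl on an amide-type nitrogen.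

Compound 3 (`COc1cc(NC(C)CCCNC(=O)NNC(=O)Nc2cccc(F)c2)c2ncccc2c1`) departs from compound 2 at that same place, with ((3-fluorophenyl)carbamoyl)amino in place of 3-hydroxyphenyl on an amide-type nitrogen whose other neighbour is the carbonyl carbon: ((3-fluorophenyl)carbamoyl)amino in place of 3-hydroxyphenyl on an amide-type nitrogen. The measured step bears on this change only in part, since it shows one exchange of the group at this place with no visible effect. For the measured compounds named here, no measured compound carries the entering group, so the evidence is thin and the range must stay wide. In this assay no step beyond the scatter is expected. The estimated step is a 1.2-fold lower number from compound 2 to compound 3 (0.08 log units; within the scatter) on present evidence. For compound 3 the expected value is 20000 nM with an estimated range from 6000 nM to 60000 nM for now.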

Compound 3, half-maximal inhibitory concentration: >= 250000 nM
Compound 3: no number, only a limit; the forecaster's own chance of this, stated with the estimate: 20%; middle value at least 12-fold (1.09 log units) away from the limit.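

For compound 3 the reading in this assay is a limit of the assay and not a number: the limit of >= 250000 nM in this assay, at which 1 of the 3 values shown sits. With compound 1 and compound 2 standing level, the earlier pair gave no sign that the group on this amide-type nitrogen could matter, yet ((3-fluorophenyl)carbamoyl)amino gives an at least 10-fold higher number from compound 2 to compound 3 (1.01 log units; beyond the scatter) and an at least 10-fold higher number from compound 1 to compound 3 (1.00 log units; beyond the scatter). This place therefore does respond to the choice of group, at least for this exchange, and the two phenyl groups that stand level are not a guide to every group placed there; the full size of both steps stays unread, since only a limit is available on the side of compound 3.

The entering group differs from the other two in more than one respect, carrying both the carbamoylamino link and a fluorine on the ring, and the compounds shown do not separate these two features. A plain 3-fluorophenyl group on the same nitrogen would address the ring alone, while a benzyl or 2-phenylethyl group would show how a longer link without the carbamoylamino unit reads in this position.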